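Aryl swap on the shared core: compound 1 to compound 4

The compounds below may be only part of what the source reports. "The series", "measured", "known", "first", "only" and "open" are said of these compounds alone.

Compound 1 `CC(C)(C)n1ncc(OCc2nnc(-c3ccccc3Cl)o2)c(Cl)c1=O` gives 61.2 ug/mL in a functional assay on the whole organism for inhibition, with Mythimna separata as the target, with a stated time of 5 days (a lower number here means that less compound is needed, a higher number that more compound is needed for the effect), the lowest of the two numbers shown, though compound 2 `CC(C)(C)n1ncc(OCc2nnc(-c3ccc(Cl)cc3)s2)c(Cl)c1=O` with 106 ug/mL lies within the scatter of it. Compound 3 `Cc1cc(C)cc(-c2nnc(COc3cnn(C(C)(C)C)c(=O)c3Cl)s2)c1` reaches only the limit > 300 ug/mL in this assay. For the measured compounds named here, the single sized step, an at least 2.8-fold higher number from compound 2 to compound 3 (0.45 log units; beyond the scatter), has its size set only as a floor by the limit of > 300 ug/mL in this assay, at which 1 of the 3 values shown sits. Compound 4 `CC(C)(C)n1ncc(OCc2nnc(-c3cc(F)c(F)cc3F)o2)c(Cl)c1=O` differs from compound 1 by 2,4,5-trifluorophenyl in place of 2-chlorophenyl on an aromatic carbon. This exchanges one halogenated phenyl for another, whereas the measured step exchanges a chlorophenyl for a dimethylphenyl, so it does not bear on the change directly. No step beyond the scatter is expected in this assay. For compound 4 the estimate is 80 ug/mL, with a range of 30 ug/mL to 250 ug/mL. The expected step is a 1.3-fold higher number from compound 1 to compound 4 (0.12 log units; within the scatter).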

Compound 4, half-maximal effective concentration: 75.7 ug/mL
Compound 4: middle estimate off by 1.1-fold (0.02 log units), on the high side; low and high end bracket the measured number.
By their numbers in this assay, from the lowest: compounds 1, 4 and 2 (each within the scatter of the next). At a limit, above all of these: compound 3.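

In this assay, 2,4,5-trifluorophenyl in place of 2-chlorophenyl gives a 1.2-fold higher number from compound 1 to compound 4 (0.09 log units; within the scatter). For the compounds shown here, this position, on the aromatic carbon next to the ring oxygen, therefore accepts a second halogenated phenyl on the same core without a step beyond the scatter, a comparison the earlier compounds did not offer. Nothing measured here accounts for this result.

Still open, as far as these compounds go, is whether a methoxyphenyl or an aminophenyl at this position would stay within the scatter of compound 1. Also open, from the compounds shown here alone, is how 3,5-dimethylphenyl behaves on the core of compound 1.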